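The source may report more compounds than this note shows. Statements on the series, on what has been measured and on what is new or still open speak of the compounds shown alone.

Measured so far in an in vitro ADME assay on microsomes from liver (Rattus norvegicus) for metabolic stability; a higher number here means faster removal of the compound, a lower number slower removal:

compound 1 `CCC(CC)[C@@H]1C(=O)N[C@H](C2Cc3ccccc3C2)C(=O)N1[C@@H](C(=O)N1CCOCC1)c1ccc(C)nc1`: 1 mL.min-1.g-1
compound 2 `CCC(CC)[C@@H]1C(=O)N[C@H](C2Cc3ccccc3C2)C(=O)N1[C@@H](C(=O)N1CCOCC1)c1ccc(C)nc1C`: 1 mL.min-1.g-1
compound 3 `CCC(CC)[C@@H]1C(=O)N[C@H](C2Cc3ccccc3C2)C(=O)N1[C@@H](C(=O)N(C)C)c1ccc(C)nc1`: 2 mL.min-1.g-1

Compound 1 stands level with compound 2, and all three numbers lie within the usual scatter of one another. The open question is compound 4 `CC[C@@H](C)[C@@H]1C(=O)N[C@H](C2Cc3ccccc3C2)C(=O)N1[C@@H](C(=O)N1CCOCC1)c1ccc(C)nc1`, which keeps the core of compound 1 but carries sec-butyl in place of pentan-3-yl on a saturated ring carbon. Going by the values given here, no measured step touches that place, so the only guides are changes elsewhere in the molecule. Methyl in place of hydrogen on an aromatic carbon gave no change at the digits printed from compound 1 to compound 2 (within the scatter), and dimethylamino in place of morpholin-4-yl on a carbonyl carbon gave a 2.0-fold higher number from compound 1 to compound 3 (0.30 log units; within the scatter). Neither step goes beyond the scatter, and neither speaks directly to this swap. No step beyond the scatter is therefore expected in this assay. The estimated step is no change at the digits printed from compound 1 to compound 4 (within the scatter). Compound 4 is expected at 1 mL.min-1.g-1, with an estimated range from 0.5 mL.min-1.g-1 to 3 mL.min-1.g-1.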

Compound 4, intrinsic clearance in microsomes: 1 mL.min-1.g-1
The estimate for compound 4 equals the measured number at the digits printed; low and high end bracket the measured number.
By their numbers in this assay, from the lowest: compounds 1, 2, 4 and 3 (each within the scatter of the next).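

Compound 4 is the first change shown at this saturated ring carbon, and in this assay sec-butyl in place of pentan-3-yl gives no change at the digits printed from compound 1 to compound 4 (within the scatter) and so stays within the usual scatter. At this position, then, going from 5 heavy atoms to 4 and adding a defined stereocentre leaves the clearance reading unmoved in this pair. No measurement at hand offers a reason for this outcome.

The compounds shown carry only these two branched carbon groups here, so a methyl, a cyclohexyl ring or a chain ending in an amine remains an open case. Also open, from the compounds shown here alone, is the other stereoisomer of sec-butyl, and whether sec-butyl gives the same reading when dimethylamino replaces morpholin-4-yl on the carbonyl carbon.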